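Aryl cyanoacrylic acids: a fourth substituent on the ring

This account rests on a few compounds, and the source may have more. Where it says the series, first, only, none or still open, it means among the compounds named here.

Measured so far in an assay on RBE4 cells for inhibition of Monocarboxylate transporter 1 (Rattus norvegicus), with a stated time of 15 min; on this read-out lower numbers stand for stronger inhibition and higher numbers for weaker inhibition:
compound 1 `CCc1ccc(/C=C(\C#N)C(=O)O)cc1` — 500 nM
compound 2 `N#C/C(=C\c1ccc(Cl)cc1)C(=O)O` — 500 nM
compound 3 `N#C/C(=C\c1ccc([N+](=O)[O-])cc1)C(=O)O` — 500 nM

Compound 3 stands level with the other two on the numbers shown. The step from compound 1 to compound 3, no change at the digits printed from compound 1 to compound 3 (within the scatter), and the step from compound 2 to compound 3, no change at the digits printed from compound 2 to compound 3 (within the scatter), both fall within the scatter, as does no change at the digits printed from compound 1 to compound 2 (within the scatter). Across ethyl, chloro and nitro on the same aromatic carbon of the shared core, this assay reports one value.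

Compound 4 `CN(C)c1ccc(/C=C(\C#N)C(=O)O)cc1` is the next point in the set. The change is dimethylamino in place of nitro on an aromatic carbon. All three measured steps bear on it, since each swaps one group for another at the same place, and none of them moved the read-out beyond the scatter. Among the compounds with values here, no measured step involves dimethylamino itself, so the expectation rests only on the flat run seen with the three groups already tried. The expected step from compound 3 to compound 4 is therefore no change at the digits printed from compound 3 to compound 4 (within the scatter), no change beyond the scatter in this assay. Compound 4 is estimated at 500 nM, with a range from 200 nM to 1500 nM.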

Compound 4, half-maximal inhibitory concentration: 140 nM
Estimate against measurement, compound 4: 3.6-fold (0.55 log units) above; measured number below the stated range.
By their numbers in this assay, from the lowest: compound 4; then compounds 1, 2 and 3 (each within the scatter of the next).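

In this assay, within the data shown here, this position turns out not to be flat: dimethylamino is the first group to move the read-out beyond the scatter, and the lower number holds against all three earlier groups, against nitro (a 3.6-fold lower number from compound 3 to compound 4 (0.55 log units; beyond the scatter)), against chloro (a 3.6-fold lower number from compound 2 to compound 4 (0.55 log units; beyond the scatter)) and against ethyl (a 3.6-fold lower number from compound 1 to compound 4 (0.55 log units; beyond the scatter)). The position therefore responds to the group placed on it, even though ethyl, chloro and nitro could not be told apart, and the count of heavy atoms does not separate compound 3 from compound 4, since nitro and dimethylamino carry the same count. No measurement in hand accounts for why dimethylamino stands apart from the other three groups.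

The compounds shown leave open whether the lower number belongs to dimethylamino alone or also extends to a primary amine, a methylamino group, a diethylamino group or a methoxy group at the same aromatic carbon. They also leave open whether dimethylamino gives the same step when it sits on a different carbon of the ring, or when a second group such as a hydroxyl is added to the ring.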